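From methyl to allyloxy on an aromatic nitrogen

The compounds below may be only part of what the source reports. "The series", "measured", "known", "first", "only" and "open" are said of these compounds alone.

Measured so far, all in (a functional assay on a cell-free system (plasma, Oryctolagus cuniculus) for inhibition, with stated times of 5 min, 1 min and 6 min; a lower number here means a stronger inhibitor, a higher number a weaker inhibitor)
- compound 1 (`CCOC(=O)c1c(C)nc(-c2ccccc2C#N)n1OC`): (14900 nM)
- compound 2 (`CCOC(=O)c1c(C)nc(-c2ccc(C#N)cc2)n1OC`): (13400 nM)
- compound 3 (`CCOC(=O)c1c(C)nc(-c2cccc(C#N)c2)n1C`): (22100 nM)

In (this assay) compound 3 gives (22100 nM), a number within the usual scatter of those of compound 1 and compound 2. The three compounds therefore cannot be ranked on these data.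

Compound 4 (`C=CCOn1c(-c2cccc(C#N)c2)nc(C)c1C(=O)OCC`) has not yet been measured. It differs from compound 3 by allyloxy in place of methyl on an aromatic nitrogen. Going by the values given here, no measured pair of compounds differs in one place only, so the data give no direct guide to the size of this step. The expectation rests only on how close together the three numbers lie, with compound 1 at (14900 nM) and compound 2 at (13400 nM). A step in (this assay) that stays within the scatter is expected, perhaps towards a slightly lower number, and the estimate is (a 1.5-fold lower number from compound 3 to compound 4 (0.17 log units; within the scatter)). For compound 4 the estimated value is (15000 nM), with an expected range from (6000 nM) to (35000 nM).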

Compound 4, half-maximal inhibitory concentration: 5860 nM
Beside the measured number, compound 4's estimate is 2.6-fold (0.41 log units) above it; measured number outside the range, below it.
By their numbers in this assay, from the lowest: compound 4; then compounds 2, 1 and 3 (each within the scatter of the next).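

In this assay, going by these compounds alone, putting allyloxy in place of methyl on an aromatic nitrogen gives a 3.8-fold lower number from compound 3 to compound 4 (0.58 log units; beyond the scatter) and so provides the first reading of a change in one place, a modest step that lies beyond the scatter. This nitrogen therefore responds to the group it carries, at least across this one pair, and the number falls when allyloxy enters. Nothing available here accounts for the size or direction of this step.

Allyloxy brings an oxygen and a double bond together, so the compounds shown do not tell which of these parts goes with the lower number. On these data alone, a propyloxy chain on the same nitrogen would keep the oxygen without the double bond, while a butenyl chain would keep the double bond without the oxygen, and how either would read remains open.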